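Methoxy added to the phenyl of compound 1

A few compounds are considered here, and "the series" means these few. Any claim that something is new, unique, unknown or untested is made for them only; others in the source may bear on it.

Measured compounds:
compound 1, `COc1ccc(Cn2cc(CNC(=O)c3cn(-c4ccccc4)nc3-c3ccccc3)nn2)cc1`: > 100000 nM
compound 2, `COc1cc(Cn2cc(CNC(=O)c3cn(-c4ccccc4)nc3-c3ccccc3)nn2)cc(OC)c1OC`: > 100000 nM

Compound 1, `COc1ccc(Cn2cc(CNC(=O)c3cn(-c4ccccc4)nc3-c3ccccc3)nn2)cc1`, in a functional assay on MCF7 cells (Homo sapiens) for antiproliferative activity, read by sulforhodamine B assay, with a stated time of 48 h (on this read-out higher numbers stand for weaker inhibition of growth and lower numbers for stronger inhibition of growth), gives > 100000 nM, which is a limit of the assay and not a number. Compound 2, `COc1cc(Cn2cc(CNC(=O)c3cn(-c4ccccc4)nc3-c3ccccc3)nn2)cc(OC)c1OC`, in this assay gives > 100000 nM, also a limit. The step that the two limits leave unreadable from compound 1 to compound 2 can therefore not be read. Both values sit at the limit of > 100000 nM in this assay, at which 2 of the 2 values shown sit, so compound 1 stands at the limit and nowhere else on the shown numbers.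

Compound 3, `COc1ccc(Cn2cc(CNC(=O)c3cn(-c4ccccc4)nc3-c3ccc(OC)cc3)nn2)cc1`, differs from compound 1 by methoxy in place of hydrogen on an aromatic carbon. Among the measured compounds shown here, no measured step bears on this change; the only measured step, from compound 1 to compound 2, is unreadable. With both shown values at the limit, no direction of change can be drawn from the data. Compound 3 is expected to give 100000 nM, in a range from 20000 nM to 300000 nM, most probably again as a limit. The expected step of a number no higher from compound 1 to compound 3 (the limit leaves the size open) is thus estimated to stay within the scatter.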

Compound 3, concentration for 50% growth inhibition: 22900 nM
Estimate against measurement, compound 3: 4.4-fold (0.64 log units) above; the measured number falls inside the stated range.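

Among the compounds shown here, the one earlier step, 3,4,5-trimethoxyphenyl in place of 4-methoxyphenyl, cannot be read, whereas in this assay the change of phenyl to 4-methoxyphenyl, para to a large group, gives an at least 4.3-fold lower number from compound 1 to compound 3 (0.64 log units; beyond the scatter). For compound 1, > 100000 nM is a limit of the assay and not a number. For the compounds shown here, compound 3 is therefore the only one of the three compounds that gives a number and not a limit: the limit of > 100000 nM in this assay, at which 2 of the 3 values shown sit.

The compounds shown leave open whether this step is particular to methoxy, since no other group, such as a hydroxyl, an amine or a chlorine, stands at this place. They also leave open whether 3,4,5-trimethoxyphenyl in place of 4-methoxyphenyl would have a readable effect on the core of compound 3.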